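A chloro group added to compound 3

A few compounds are considered here, and "the series" means these few. Any claim that something is new, unique, unknown or untested is made for them only; others in the source may bear on it.

Of the compounds shown here, three have so far been measured in a functional assay on thoracic aorta (Rattus norvegicus, strain Wistar), with a stated time of 15 min; on this read-out lower numbers stand for an effect already at smaller amounts and higher numbers for an effect only at larger amounts of compound. Compound 1 (`CC(NC(=O)NS(=O)(=O)c1ccc(Cl)cc1)c1ccccc1OCc1ccccc1`) gives 157000 nM, and compound 2 (`CC(NC(=O)N(C)S(=O)(=O)c1ccc(Cl)cc1)c1cc(Br)ccc1OCc1ccccc1`) gives 146000 nM, a closely similar number. Compound 3 (`CC(NC(=O)N(C)S(=O)(=O)c1ccccc1)c1ccccc1OCc1ccccc1`) gives 21700 nM, the lowest of the three, and both other numbers lie above it by more than the usual scatter.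

The next compound to be tested is compound 4 (`CC(NC(=O)N(C)S(=O)(=O)c1ccc(Cl)cc1)c1ccccc1OCc1ccccc1`), which differs from compound 3 in one place: chloro in place of hydrogen on an aromatic carbon. The chloro group replaces a hydrogen on an aromatic carbon of a six-membered aromatic ring of carbon only, para to a large group, turning phenylsulfonyl into (4-chlorophenyl)sulfonyl.

Going by the values given here, no measured pair isolates this change, so the evidence is indirect. Compound 1, at 157000 nM, and compound 2, at 146000 nM, both carry the 4-chlorophenyl group, but each also differs from compound 3 elsewhere. A moderate rise in the number is therefore expected in this assay, probably beyond the scatter, though a smaller change cannot be excluded. The expected change is a 2.3-fold higher number from compound 3 to compound 4 (0.36 log units; beyond the scatter). For compound 4 the estimated value is 50000 nM, with an expected range from 15000 nM to 160000 nM.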

Compound 4, half-maximal effective concentration: 38400 nM
Beside the measured number, compound 4's estimate is 1.3-fold (0.11 log units) above it; the measured number falls inside the stated range.
By their numbers in this assay, from the lowest: compounds 3 and 4 (each within the scatter of the next); then compounds 2 and 1 (each within the scatter of the next).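

Turning phenylsulfonyl into (4-chlorophenyl)sulfonyl gives a 1.8-fold higher number from compound 3 to compound 4 (0.25 log units; within the scatter) in this assay and so stays within the scatter, which means that on this aromatic carbon, para to a large group, chloro cannot be told apart from hydrogen on this read-out. The high numbers of the two earlier compounds, which also carry the 4-chlorophenyl group, therefore go with their other differences: hydrogen in place of bromo on an aromatic carbon gives a 3.8-fold lower number from compound 2 to compound 4 (0.58 log units; beyond the scatter) and is beyond the scatter, as is methyl in place of hydrogen on an amide-type nitrogen, which gives a 4.1-fold lower number from compound 1 to compound 4 (0.61 log units; beyond the scatter) on the same read-out. No measured evidence is available to explain why the chloro step is so small while these two steps are larger.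

From the compounds shown here alone, it remains open whether this carbon tolerates groups other than chloro in the same way, for example a methoxy group, an amine or a carboxylic acid. The compounds shown also leave open whether chloro would remain within the scatter of hydrogen in a compound carrying the bromo group or the amide hydrogen.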